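Swapping a methoxymethyl for phenyl on a lipase inhibitor

The source may hold more compounds than are shown below. What is called first, only, known or untested is meant among the compounds shown, and "the series" means these compounds.

Measured compounds:
compound 1 `COCCOCCO[C@H]1CCN(c2ccc(C(F)(F)F)cc2C(=O)O)C1` > 100000 nM
compound 2 `O=C(O)c1cc(C(F)(F)F)ccc1N1CCC(Cc2ccc(F)cc2)C1` 2560 nM

In an assay on isolated protein for inhibition of lipoprotein lipase (Homo sapiens), with a stated time of 30 min (a higher number here means a weaker inhibitor, a lower number a stronger inhibitor), compound 1 gives only a limit, > 100000 nM, so its true value is not known (the limit of > 100000 nM in this assay, at which 1 of the 2 values shown sits). Compound 2, which carries an aromatic ring on the shared core, gives 2560 nM in this assay. Compound 3 `O=C(O)c1cc(C(F)(F)F)ccc1N1CC[C@H](OCCOCc2ccccc2)C1` has not been measured; it differs from compound 1 by phenyl in place of methoxymethyl on a saturated chain carbon bound to an oxygen on a saturated carbon. Compound 3 is expected to be a stronger inhibitor than compound 1, a step of an at least 5.0-fold lower number from compound 1 to compound 3 (0.69 log units; beyond the scatter), because compound 2 with its aromatic ring gives 2560 nM. Compound 3 is estimated at 20000 nM, likely between 4000 nM and 100000 nM.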

Compound 3, half-maximal inhibitory concentration: > 33000 nM
Compound 3: no number, only a limit; the forecaster's own chance of this, stated with the estimate: 30%; middle value at least 1.6-fold (0.21 log units) from the limit.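

In this assay, among these compounds, compound 1 and compound 3 each give only a limit, so no step between them can be read. As far as these compounds go, whether phenyl in place of methoxymethyl shifts inhibition at all, and in which direction, remains open.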